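The source may report more compounds than this note shows. Statements on the series, on what has been measured and on what is new or still open speak of the compounds shown alone.

Compound 2, with structure `COc1nc(=O)ccn1[C@@H]1O[C@H](COP(=O)(O)OP(=O)(O)O)[C@@H](O)[C@H]1O`, holds the only numerical result in an in vitro functional assay on 1321-N1 cells for agonist activity at P2Y purinoceptor 6 (Homo sapiens), read by scintillation proximity assay and inositol phosphate accumulation (a lower number here means that less compound is needed, a higher number that more compound is needed for the effect), where compound 2 gives 1370 nM. Compound 1, with structure `Nc1nc(=O)ccn1[C@@H]1O[C@H](COP(=O)(O)OP(=O)(O)O)[C@@H](O)[C@H]1O`, differs from it only by an amino group in place of the methoxy group, and in this assay compound 1 reaches only the limit of >= 100000 nM. Among the measured compounds shown here, the step of an at least 72-fold lower number from compound 1 to compound 2 (1.86 log units; beyond the scatter) is therefore the single measured change at this position, and its size is bounded by the limit of >= 100000 nM in this assay, at which 1 of the 2 values shown sits, rather than fixed exactly.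

Compound 3, with structure `O=c1ccn([C@@H]2O[C@H](COP(=O)(O)OP(=O)(O)O)[C@@H](O)[C@H]2O)c(SCc2ccccc2)n1`, is the next step from compound 2: benzylsulfanyl in place of methoxy on an aromatic carbon. For the measured compounds named here, the one measured step concerns the same position, from amino to methoxy, and it was large; it does not say whether a larger group such as benzylsulfanyl will help or hurt. The two groups that have been measured give no pattern to extend, so the expectation is a step of a 1.5-fold higher number from compound 2 to compound 3 (0.16 log units; within the scatter) of uncertain direction, most likely within or near the scatter, with a wide range. Compound 3 is therefore estimated at 2000 nM in this assay, between 300 nM and 15000 nM.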

Compound 3, half-maximal effective concentration: 6800 nM
The estimate for compound 3 lay 3.4-fold (0.53 log units) below the measured number, and the stated range covers the measured number.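

With benzylsulfanyl in place of methoxy, this assay shows a 5.0-fold higher number from compound 2 to compound 3 (0.70 log units; beyond the scatter), so this position, between two ring nitrogen atoms, still gives a measurable number with a much larger group carrying an aromatic ring of carbon only, though not as low a number as with methoxy. Benzylsulfanyl in place of amino shows an at least 14-fold lower number from compound 1 to compound 3 (1.16 log units; beyond the scatter), so among the three groups shown, methoxy gives the lowest number, benzylsulfanyl a higher one and amino the highest, and the gain over amino is not confined to methoxy. The value of compound 1 is a limit and not a number, so the size of this last step remains bounded rather than fixed: the limit of >= 100000 nM in this assay, at which 1 of the 3 values shown sits.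

The compounds shown do not separate the part played by the sulfur atom from that of the benzyl group, a question that a methylsulfanyl or a benzyloxy group at this position would address. They also leave open whether a group of intermediate length, such as ethoxy or ethylsulfanyl, would give a number lower than that of compound 2 or a higher one.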